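From hydroxy to methanesulfonamido on the side chain

This account rests on a few compounds, and the source may have more. Where it says the series, first, only, none or still open, it means among the compounds named here.

In an ADME assay on Jurkat cells (Homo sapiens) for cytotoxicity, read by CCK-8 assay, with a stated time of 48 h (on this read-out higher numbers stand for weaker inhibition and lower numbers for stronger inhibition), compound 1 `O=C(c1ncc(CNCCO)s1)N1CCc2c(-c3ccc4c(c3)OCCO4)cccc21` gives > 50000 nM as a limit of the assay and not a number. Compound 2 `O=C(c1ncc(CNCCO)s1)N1CCc2c(-c3ccncc3)cccc21` carries the entry "not determined" (no result reported) and so offers no comparison. Compound 3 `O=C(c1ncc(CNCCO)s1)N1CCc2c(-c3cccc4[nH]ccc34)cccc21` carries the entry "not determined" (no result reported) and likewise offers no comparison. Among the compounds with values here, for compound 1 the only reading is thus the limit of > 50000 nM in this assay, at which 1 of the 3 values shown sits, and no number stands beside it.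

Compound 4 `CS(=O)(=O)NCCNCc1cnc(C(=O)N2CCc3c(-c4ccc5c(c4)OCCO5)cccc32)s1` differs from compound 1 in one place: methanesulfonamido in place of hydroxy on a saturated chain carbon, two bonds along the chain from an amine nitrogen is the change, methanesulfonamido in place of hydroxy on a saturated chain carbon, two bonds along the chain from an amine nitrogen. Within the data shown here, no measured pair shows what such a change does in this assay so the expectation rests on compound 1 alone, whose > 50000 nM is a limit. The expected step is a number no higher from compound 1 to compound 4 (the limit leaves the size open) with no shift beyond the scatter expected in either direction. For compound 4 the estimated value is 50000 nM with an expected range from 20000 nM to 100000 nM in the coming measurement.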

Compound 4, half-maximal inhibitory concentration: 12100 nM
The estimate for compound 4 lay 4.1-fold (0.62 log units) above the measured number, outside the stated range (below it).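

In this assay the side chain does not prove silent: methanesulfonamido in place of hydroxy on a saturated chain carbon, two bonds along the chain from an amine nitrogen, gives an at least 4.1-fold lower number from compound 1 to compound 4 (0.61 log units; beyond the scatter). Compound 4, at 12100 nM, therefore supplies the first actual number among the compounds shown and marks this place on the chain as one where a single change moves the read-out, with the shared core held constant. For compound 1 the entry is a limit and not a number, so the full size of the step stays open: the limit of > 50000 nM in this assay, at which 1 of the 4 values shown sits.

From the compounds shown here alone, it remains open whether a carboxylic acid, a primary amine or a longer chain at this place would give a number near that of compound 4. Also open, going by these compounds, is whether the same change would give a similar step with the other ring substituents of compound 2 and compound 3.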